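The source may report more compounds than this note shows. Statements on the series, on what has been measured and on what is new or still open speak of the compounds shown alone.

Measured in a functional assay on MIA PaCa-2 cells (Homo sapiens) for cytotoxicity, read by MTT assay, with a stated time of 72 h; on this read-out lower numbers stand for stronger inhibition and higher numbers for weaker inhibition:
- compound 1 `Nc1ccc(-c2ccc(NC3=CC(=O)c4ncncc4C3=O)cc2)cc1`: 2500 nM
- compound 2 `COc1ccc(-c2ccc(NC3=CC(=O)c4ncncc4C3=O)cc2)cc1`: 2100 nM

Compound 2, at 2100 nM, stands level with compound 1 at 2500 nM, as the two values lie within the scatter of each other. Compound 3 `O=C1C(Nc2ccc(CO)cc2)=CC(=O)c2ncncc21` departs from compound 2 by hydroxymethyl in place of 4-methoxyphenyl on an aromatic carbon. For the measured compounds named here, only one measured step bears on this, and it bears weakly: a 1.2-fold lower number from compound 1 to compound 2 (0.08 log units; within the scatter). Going by the values given here, that step exchanges one group on the ring that compound 3 loses, and no measured pair shows the loss of the ring itself. The data therefore suggest no direction, and no change beyond the scatter is expected, though the uncertainty is wide. The expected step is a 1.1-fold lower number from compound 2 to compound 3 (0.02 log units; within the scatter). For compound 3 the estimated value is 2000 nM, with an expected range from 500 nM to 8000 nM.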

Compound 3, half-maximal inhibitory concentration: 3500 nM
Compound 3: the middle estimate sits 1.8-fold (0.24 log units) below what was measured, and the stated range covers the measured number.
By their numbers in this assay, from the lowest: compounds 2, 1 and 3 (each within the scatter of the next).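

Compound 1 and compound 2 differed only in a group carried on the outer ring, whereas compound 3 loses that six-membered aromatic ring altogether and carries hydroxymethyl in its place. In this assay, this larger change stays within the scatter by either route: (a 1.7-fold higher number from compound 2 to compound 3 (0.22 log units; within the scatter)) and (a 1.4-fold higher number from compound 1 to compound 3 (0.15 log units; within the scatter)). At this position, then, hydroxymethyl stands level with both 4-methoxyphenyl and 4-aminophenyl, and the outer ring is not needed to hold the number in this range, though nothing shown explains why.

The compounds shown leave open whether a carboxylic acid, an amine or a longer chain in place of hydroxymethyl would move the number beyond the scatter. They also leave open whether any change at this position can do so, since all three compounds lie within the scatter of the next.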